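The source may hold more compounds than are shown below. What is called first, only, known or untested is meant among the compounds shown, and "the series" means these compounds.

Compound 1 `COc1ccc2c(/C=C/C(=O)c3cc(OC)c(OC)c(SC)c3)c[nH]c2c1` and compound 2 `COc1cc(C(=O)/C=C/c2c[nH]c3ccccc23)cc(SC)c1OC` share a core and differ in one place: hydrogen in place of methoxy on an aromatic carbon. In a functional assay on HCT-8 cells (Homo sapiens) for antiproliferative activity, read by MTT assay, with a stated time of 48 h (a lower number here means a stronger inhibitor, a higher number a weaker inhibitor), compound 1 gives 138 nM, while compound 2 gives 167 nM, so the step of a 1.2-fold higher number from compound 1 to compound 2 (0.08 log units; within the scatter) is small. Compound 3 `COc1ccc2c(/C=C(\C)C(=O)c3cc(OC)c(OC)c([Se]C)c3)c[nH]c2c1` is built on a different core; the difference between the cores of compound 3 and compound 1 is not broken down here. In this assay compound 3 gives 29 nM, the lowest of the three numbers. Compound 4 `COc1cc(C(=O)/C(C)=C/c2c[nH]c3ccccc23)cc([Se]C)c1OC` repeats on compound 3 the same change: hydrogen in place of methoxy on an aromatic carbon. Because the earlier step of a 1.2-fold higher number from compound 1 to compound 2 (0.08 log units; within the scatter) stayed within the scatter, the step onto compound 4 is expected to be of similar size, a 1.2-fold higher number from compound 3 to compound 4 (0.08 log units; within the scatter). Compound 4 is therefore estimated at 35 nM, expected to lie between 15 nM and 80 nM.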

Compound 4, half-maximal inhibitory concentration: 32 nM
For compound 4 the middle estimate is 1.1-fold (0.04 log units) above the measured one; the measured number falls inside the stated range.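

In this assay, putting hydrogen in place of methoxy on an aromatic carbon gives a 1.1-fold higher number from compound 3 to compound 4 (0.04 log units; within the scatter), so on this core too the change has only a small effect on the number. The size of the step carries over from one core to the other: the same change on two cores in this assay, a 1.2-fold higher number (0.08 log units; within the scatter) from compound 1 to compound 2 and a 1.1-fold higher number (0.04 log units; within the scatter) from compound 3 to compound 4, 1.1-fold (0.04 log units) apart, within the scatter of two such steps. This rests on just two pairs of compounds in a single assay, so it does not show that the change would stay this small on any other core or in another kind of test.

The compounds shown carry only methoxy or hydrogen at this place. From the compounds shown here alone, whether a hydroxyl, an amine or a longer chain such as ethoxy on that aromatic carbon would behave the same way remains open.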